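A Fluoro Group Added to a Second Core

This account rests on a few compounds, and the source may have more. Where it says the series, first, only, none or still open, it means among the compounds named here.

Compound 1 `Fc1ccc2ncc(-c3nn[nH]n3)cc2c1` and compound 2 `Fc1cc(F)c2ncc(-c3nn[nH]n3)cc2c1` share one core; compound 3 `O=c1c(-c2nn[nH]n2)c[nH]c2ccccc12` and compound 4 `O=c1c(-c2nn[nH]n2)c[nH]c2c(F)cccc12` share another, and the difference between the two cores is not broken down here. All were examined in a functional assay on the whole organism (strain Sprague-Dawley) for inhibition, with Rattus norvegicus as the target; a lower number here means that less compound is needed, a higher number that more compound is needed for the effect. For compound 1 this assay reports only a limit, < 25 mg/kg, and not a number. Compound 2 gives 10 mg/kg. The change between them, (fluoro in place of hydrogen on an aromatic carbon), makes a step that the limit leaves unreadable from compound 1 to compound 2, because of the limit of < 25 mg/kg in this assay, at which 1 of the 3 values shown sits. Compound 3 gives 1.25 mg/kg, the lowest of the two numbers; its gap to compound 2, the nearest, lies beyond the usual scatter.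

Compound 4 differs from compound 3 by fluoro in place of hydrogen on an aromatic carbon. This is the same kind of change as that from compound 1 to compound 2, but not the same change: in compound 2 the new fluoro stands meta to a fluoro group, whereas around the place in compound 4 no fluoro group is counted.

Among the compounds with values here, the one measured example of this kind of change gives no readable size, so the expectation for compound 4 rests on compound 3 alone. The step from compound 3 to compound 4 is expected to be no change at the digits printed from compound 3 to compound 4 (within the scatter). Compound 4 is therefore estimated at 1.25 mg/kg, with the likely range running from 0.5 mg/kg to 3 mg/kg.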

Compound 4, minimum effective dose: 0.625 mg/kg
Compound 4: middle estimate off by 2.0-fold (0.30 log units), on the high side, within the range that was stated.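

On the core shared by compound 3 and compound 4, fluoro in place of hydrogen on an aromatic carbon gives in this assay a 2.0-fold lower number from compound 3 to compound 4 (0.30 log units; within the scatter) and so the two compounds cannot be told apart by this measurement. This shows that, on this core and at this one place, the change left the dose needed inside the normal variation between repeated measurements; it does not show a real gain or a real loss, and one readable step cannot show whether a fluoro group acts alike on both cores. The matching step on the other core offers nothing to set beside it, because compound 1 carries a limit and not a number: (the limit of < 25 mg/kg in this assay, at which 1 of the 4 values shown sits).

As far as these compounds go, what a different group would do at the place ortho to a fused ring stays open: a chloro group, a methoxy group or an amine there could be compared directly with compound 3, since each would differ from it in one place only. Also open, from the compounds shown here alone, is whether a fluoro group at another aromatic carbon of the core of compound 3 would give a step that stands clear of the scatter.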